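Ring nitrogen placement on the acetamide of a triazole series

The source may report more compounds than this note shows. Statements on the series, on what has been measured and on what is new or still open speak of the compounds shown alone.

Compound 1: `CCc1ccc(Cn2c(CCc3ccccc3)nnc2[C@H](NC(=O)c2ccncc2)c2c[nH]c3ccccc23)cc1` gives > 1000 nM in an in vitro assay on LLC-PK1 cells for displacement of a labelled ligand from growth hormone secretagogue receptor type 1 (Homo sapiens) (a higher number here means a weaker inhibitor, a lower number a stronger inhibitor), a limit of the assay.
Compound 2: `CCc1ccc(Cn2c(CCc3ccccc3)nnc2[C@H](NC(=O)Cc2ccccn2)c2c[nH]c3ccccc23)cc1` gives 51 nM in this assay.

Two compounds sharing one core differ only in the amide cap. Compound 1 reaches only a limit in this assay. Compound 2 gives the single true number shown, so it is the only compound placed on the scale, and the step of an at least 19-fold lower number from compound 1 to compound 2 (1.29 log units; beyond the scatter) describes the gap to the limit, as noted in the limit of > 1000 nM in this assay, at which 1 of the 2 values shown sits.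

Compound 3, `CCc1ccc(Cn2c(CCc3ccccc3)nnc2[C@H](NC(=O)Cc2cccnc2)c2c[nH]c3ccccc23)cc1`, has not been measured. It differs from compound 2 by pyridin-3-yl in place of pyridin-2-yl on a saturated chain carbon bound to a carbonyl carbon. Among the measured compounds shown here, only one measured step exists, and it moved both the chain length and the ring nitrogen at once, so it bears on this change only loosely. The smaller change here is expected to shift the number modestly, with a lean toward a weaker value: the step of a 2.0-fold higher number from compound 2 to compound 3 (0.29 log units; within the scatter) is the estimate. Compound 3 is therefore expected to give 100 nM, between 35 nM and 300 nM.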

Compound 3, half-maximal inhibitory concentration: 480 nM
Beside the measured number, compound 3's estimate is 4.8-fold (0.68 log units) below it; the measured number lies above the stated range.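

In this assay, the exchange of pyridin-2-yl for pyridin-3-yl on a saturated chain carbon bound to a carbonyl carbon gives a 9.4-fold higher number from compound 2 to compound 3 (0.97 log units; beyond the scatter). The earlier step changed the chain and the ring nitrogen together, whereas this one holds the chain fixed and shows that the ring nitrogen placement alone moves the number beyond the scatter. Compound 1 remains a limit, so an at least 2.0-fold lower number from compound 1 to compound 3 (0.31 log units; beyond the scatter) is only a bound, and compound 3 still reads clear of that limit: the limit of > 1000 nM in this assay, at which 1 of the 3 values shown sits.

The compounds shown leave open how (pyridin-4-yl)methyl would read on the same carbonyl, so the share of the chain and the share of the ring nitrogen in the steps from compound 1 remain apart. They also leave open whether a plain phenyl ring or a longer chain in this place would hold the number of compound 2.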